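Replacing One Side Group of Compound 1 With Carbamoyl

The compounds below may be only part of what the source reports. "The series", "measured", "known", "first", "only" and "open" are said of these compounds alone.

Compound 1 `Cn1ncc(Cl)c1-c1cc(C(=O)N[C@@H]2CN[C@H](CCN3CCC(O)CC3)C[C@H]2c2ccc(Cl)c(Cl)c2)oc1Cl` is the starting point here. Among the measured compounds shown here, in a functional assay on OVCAR-8 cells (Homo sapiens) for antiproliferative activity (a lower number here means a stronger inhibitor, a higher number a weaker inhibitor), compound 1 gives 15900 nM, the higher of the two numbers so far. For the measured compounds named here, the only other measured compound, compound 2 `Cn1ncc(Cl)c1-c1cc(C(=O)N[C@@H]2CN[C@H](CCO)C[C@H]2c2ccc(F)c(F)c2)oc1Cl`, gives 460 nM, a gap well beyond the scatter. Compound 3 `Cn1ncc(Cl)c1-c1cc(C(=O)N[C@@H]2CN[C@H](CC(N)=O)C[C@H]2c2ccc(Cl)c(Cl)c2)oc1Cl` has not yet been measured. It keeps the core of compound 1 but has carbamoyl in place of (4-hydroxypiperidin-1-yl)methyl on a saturated chain carbon bound to a saturated ring carbon. Going by the values given here, no measured pair isolates this change, so any forecast is rough. Compound 2 also lacks that group and gives 460 nM, though it differs elsewhere too. A clear move towards a lower number in this assay is therefore expected, with an estimated step of an 11-fold lower number from compound 1 to compound 3 (1.03 log units; beyond the scatter). For compound 3 the expected value is 1500 nM, within an estimated range of 300 nM to 8000 nM.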

Compound 3, half-maximal inhibitory concentration: 1000 nM
Beside the measured number, compound 3's estimate is 1.5-fold (0.18 log units) above it; the measured number falls inside the stated range.
By their numbers in this assay, from the lowest: compound 2; then compound 3; then compound 1.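

Among the compounds shown here, with the rest of compound 1 held fixed, this is the first single change that can be read on its own. In this assay, putting carbamoyl in place of (4-hydroxypiperidin-1-yl)methyl on a saturated chain carbon bound to a saturated ring carbon gives a 16-fold lower number from compound 1 to compound 3 (1.20 log units; beyond the scatter), a large step, so this side group alone strongly affects the number, and the smaller group without a ring gives the lower value. Nothing shown here explains why the number falls.

The compounds shown leave open whether the step comes from losing the ring, from shortening the side chain or from the carbamoyl itself. A carboxylic acid, a primary amine or a longer chain ending in carbamoyl at this place would help separate these possibilities.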